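A few compounds are considered here, and "the series" means these few. Any claim that something is new, unique, unknown or untested is made for them only; others in the source may bear on it.

Compound 1, `O=C(CSc1nncnc1-c1cccc2ccccc12)Nc1ccccc1[N+](=O)[O-]`, in an ADME assay on MT4 cells (Homo sapiens) for cytotoxicity, read by MTT assay; on this read-out higher numbers stand for lower toxicity in this test and lower numbers for higher toxicity in this test: 142000 nM
Compound 2, `Cc1ccccc1NC(=O)CSc1nncnc1-c1ccccc1Cl`, in this assay: 142000 nM
Compound 3, `Cc1ccc(NC(=O)CSc2nncnc2-c2ccccc2Cl)c([N+](=O)[O-])c1`, in this assay: 158000 nM

All three compounds share the same core and differ only in the ring that hangs off the core and in the ring attached to the amide. In this assay compound 3 gives 158000 nM, and this number lies within the usual scatter of both compound 1 and compound 2, so the three compounds cannot be told apart on cytotoxicity here.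

Compound 4, `O=C(CSc1nncnc1-c1ccccc1Cl)Nc1ccccc1[N+](=O)[O-]`, has not been measured yet. It differs from compound 3 in one place: hydrogen in place of methyl on an aromatic carbon.

Since the three measured compounds, with their various rings, all return almost the same number, the removal of a single methyl is not expected to change this picture. The step of a 1.1-fold lower number from compound 3 to compound 4 (0.02 log units; within the scatter) is expected to stay within the scatter. Compound 4 is therefore estimated to give about 150000 nM in this assay, most likely between 75000 nM and 300000 nM.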

Compound 4, half-maximal cytotoxic concentration: 63000 nM
Compound 4: middle estimate off by 2.4-fold (0.38 log units), on the high side; the measured number lies below the stated range.
By their numbers in this assay, from the lowest: compound 4; then compounds 1, 2 and 3 (each within the scatter of the next).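

In this assay the methyl para to a large group turns out to count: a 2.5-fold lower number from compound 3 to compound 4 (0.40 log units; beyond the scatter) is beyond the scatter, and a lower number here stands for higher toxicity in this test. Compound 4 also separates from its two other neighbours, with a 2.3-fold lower number from compound 2 to compound 4 (0.35 log units; beyond the scatter) for nitro in place of methyl and a 2.3-fold lower number from compound 1 to compound 4 (0.35 log units; beyond the scatter) for 2-chlorophenyl in place of naphthalen-1-yl, so single changes can shift a series that first looked flat. No measurement at hand explains why removing the methyl has this effect.

From the compounds shown here alone, whether hydrogen is special at this aromatic carbon stays open, since a fluorine, a methoxy group or an amine there could show how the number follows the group. Also open, going by these compounds, is whether the methyl counts the same way with naphthalen-1-yl on the core.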